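Hydroxamic acid for nitrile on the chain of compound 2

This account rests on a few compounds, and the source may have more. Where it says the series, first, only, none or still open, it means among the compounds named here.

Measured compounds:
compound 1 `CCc1cc(C(C)=O)c(O)cc1OCCCCC#N` — 92%
compound 2 `C=CCc1cc(C(C)=O)c(O)cc1OCCCCCCCCCCC#N` — 50%
compound 3 `CCc1cc(C(C)=O)c(O)cc1OCCCCCC(C)(C)C#N` — 85%

In an assay on isolated protein for inhibition of leukotriene B4 receptor 1 (Homo sapiens), tested at 10 uM (on this read-out higher numbers stand for more inhibition at the one concentration tested (going by the name of the read-out) and lower numbers for less inhibition), compound 2 sits lowest of the three measured numbers; its gap to compound 3 and its gap to compound 1 both lie beyond the scatter. Compound 1 and compound 3 lie within the scatter of each other.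

The unmeasured compound 4 `C=CCc1cc(C(C)=O)c(O)cc1OCCCCCC(=O)NO` is reached from compound 2 by one change: hydroxycarbamoyl in place of 5-cyanopentyl on a saturated chain carbon, five bonds along the chain from an oxygen on an aromatic ring. Within the data shown here, the only measured step that touches the far end of the chain is the one from compound 1 to compound 3, a number 7 percentage points lower from compound 1 to compound 3 (within the scatter), which replaced one nitrile-bearing end by another and stayed within the scatter. Among the measured compounds shown here, no measured step exchanges the nitrile for a hydroxycarbamoyl group, and none shortens the chain of compound 2 on its own, since compound 1 and compound 3 differ from compound 2 in more than one place. The expectation for compound 4 therefore rests on weak ground; its chain length matches that of compound 3 rather than compound 2, so a rise is expected, but with a wide range. The step is estimated as a number 15 percentage points higher from compound 2 to compound 4 (beyond the scatter). Compound 4 is expected to give 65% in this assay, between 30% and 95%.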

Compound 4, a percentage reported as inhibition, at one concentration (the size of the read-out at that concentration, not a potency): 85%
Compound 4: the middle estimate sits 20 percentage points below what was measured; low and high end bracket the measured number.
By their numbers in this assay, from the lowest: compound 2; then compounds 3, 4 and 1 (each within the scatter of the next).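

In this assay the far end of the chain of compound 2 turns out to be a place where the read-out moves strongly: hydroxycarbamoyl in place of 5-cyanopentyl gives a number 35 percentage points higher from compound 2 to compound 4 (beyond the scatter). Among these compounds, the only earlier step at the chain end, which kept a nitrile, gave a number 7 percentage points lower from compound 1 to compound 3 (within the scatter), so a change that removes the nitrile is the first to show a step beyond the scatter at this end of the chain. The exchange is not a single simple one, as the 7 heavy atoms of 5-cyanopentyl give way to the 4 of hydroxycarbamoyl, and 2 hydrogen-bond donors enter where the leaving group has none, but nothing measured bears on why the number rises.

Compound 2 and compound 4 differ in chain length and in the end group at once, so the compounds shown leave open which of the two carries the step, and a nitrile on a chain of the same length as in compound 4 would separate them. Also open, as far as these compounds go, is how a carboxylic acid or a methyl ester at that chain end would read against hydroxycarbamoyl.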